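A Methyl on the Benzyl Ring of Compound 3

This account rests on a few compounds, and the source may have more. Where it says the series, first, only, none or still open, it means among the compounds named here.

Compound 3 `Cn1c(-c2ccc(NC(=O)CN3CCN(Cc4ccccc4)CC3)cc2)nc(-c2ccccc2)c1-c1ccccc1` carries a benzyl group on the ring amine. In a functional assay on HT-29 cells (Homo sapiens) for cytotoxicity, read by MTT assay, with a stated time of 24 h, tested at 80 ug/mL (a lower number here means a weaker effect, a higher number a stronger effect of the compound at the concentration tested), compound 3 gives 54.5%, the second highest of the three numbers measured, though within the scatter of both neighbours. Compound 1 `CN1CCN(CC(=O)Nc2ccc(-c3nc(-c4ccccc4)c(-c4ccccc4)n3C)cc2)CC1`, with methyl on that nitrogen, gives 53.1%, and compound 2 `Cn1c(-c2ccc(NC(=O)CN3CCN(c4ccccc4)CC3)cc2)nc(-c2ccccc2)c1-c1ccccc1`, with phenyl there, gives 63.7%. The step of a number 10.6 percentage points higher from compound 1 to compound 2 (beyond the scatter) is the only one beyond the scatter; a number 1.4 percentage points higher from compound 1 to compound 3 (within the scatter) and a number 9.2 percentage points lower from compound 2 to compound 3 (within the scatter) both lie within it.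

Compound 4 `Cc1ccc(CN2CCN(CC(=O)Nc3ccc(-c4nc(-c5ccccc5)c(-c5ccccc5)n4C)cc3)CC2)cc1` differs from compound 3 by methyl in place of hydrogen on an aromatic carbon. Going by the values given here, none of the measured steps alters a substituent on this aromatic ring; the nearest in kind, a number 9.2 percentage points lower from compound 2 to compound 3 (within the scatter), exchanges the group on the ring amine itself and stays within the scatter, and a number 1.4 percentage points higher from compound 1 to compound 3 (within the scatter) does the same. The change adds a single carbon far from where the measured steps vary, so no step beyond the scatter is expected, a number 0.5 percentage points higher from compound 3 to compound 4 (within the scatter). Compound 4 is therefore expected to give about 55%, between 44% and 66%.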

Compound 4, a percentage reported as activity, at one concentration (the size of the read-out at that concentration, not a potency): 54.2%
Compound 4: middle estimate off by 0.8 percentage points, on the high side; measured number inside the range.
By their numbers in this assay, from the lowest: compounds 1, 4, 3 and 2 (each within the scatter of the next, the first and the last beyond it).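

Going by these compounds alone, compound 4 is the only compound here with a change on the benzyl ring itself, and in this assay a methyl in that place gives no readable shift: a number 0.3 percentage points lower from compound 3 to compound 4 (within the scatter). Compound 4 also stays within the scatter of both other compounds, with a number 1.1 percentage points higher from compound 1 to compound 4 (within the scatter) and a number 9.5 percentage points lower from compound 2 to compound 4 (within the scatter), so 4-methylbenzyl on the ring amine cannot be told apart from methyl or phenyl there, even though the step between those two lies beyond the scatter. Nothing further is available to account for this result.

Going by these compounds, whether a methoxy group, a chlorine or a carboxylic acid in place of this methyl would move the number remains open. So does how the effects of these compounds compare at any other concentration, as each compound is read at a single concentration.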